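Removing the hydroxy from the weakest-number compound

This account rests on a few compounds, and the source may have more. Where it says the series, first, only, none or still open, it means among the compounds named here.

Compound 1 `Cc1c(C(=O)N/N=C\c2ccc(O)cc2)oc2cccc(O)c12` is a hydrazone built on a shared core, with a 4-hydroxyphenyl at its far end. Going by the values given here, in a functional assay on PC-3 cells (Homo sapiens) for inhibition (a lower number here means a stronger inhibitor, a higher number a weaker inhibitor), compound 1 gives 21700 nM, which is the only genuine number among the three measured compounds. Compound 2 `Cc1c(C(=O)N/N=C\c2cccnc2)oc2cccc(O)c12` carries pyridin-3-yl in place of that 4-hydroxyphenyl, and in this assay compound 2 reaches only the limit of >= 40000 nM. Compound 3 `Cc1c(C(=O)N/N=C\c2ccccn2)oc2cccc(O)c12` carries pyridin-2-yl, and in this assay compound 3 likewise stops at the limit of >= 40000 nM. The two steps that can be read, an at least 1.8-fold higher number from compound 1 to compound 2 (0.26 log units; that floor lies within the scatter) and an at least 1.8-fold higher number from compound 1 to compound 3 (0.26 log units; that floor lies within the scatter), both rest on (the limit of >= 40000 nM in this assay, at which 2 of the 3 values shown sit), so each is only a floor, and the third pair shows two limits and nothing more.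

Compound 4 `Cc1c(C(=O)N/N=C\c2ccccc2)oc2cccc(O)c12` differs from compound 1 by hydrogen in place of hydroxy on an aromatic carbon. Among the compounds with values here, no measured step removes only the hydroxy; the two measured steps exchange the whole ring, and each ends at a limit. They show that every change made to this ring so far has given a higher number, with no finer guide to size. Compound 4 is therefore expected to come out somewhat weaker, with a 1.6-fold higher number from compound 1 to compound 4 (0.21 log units; within the scatter) as the estimated step. For compound 4 the estimate in this assay is 35000 nM, within a range from 14000 nM to 90000 nM.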

Compound 4, half-maximal inhibitory concentration: 29200 nM
The estimate for compound 4 lay 1.2-fold (0.08 log units) above the measured number; measured number inside the range.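

In this assay, going by these compounds alone, the one step that removes only the hydroxy is a 1.3-fold higher number from compound 1 to compound 4 (0.13 log units; within the scatter), so at this place, para to a large group, hydroxy and hydrogen cannot be told apart. The earlier compounds shown here could not show this, as each of their steps exchanged the whole ring, and the hydroxy therefore does not appear to be needed for the activity seen here. The plain phenyl ring can also be set against the two pyridine rings, as an at least 1.3-fold lower number from compound 3 to compound 4 (0.13 log units; that floor lies within the scatter) and an at least 1.3-fold lower number from compound 2 to compound 4 (0.13 log units; that floor lies within the scatter), but these are floors and not sizes, and both rest on a limit: the limit of >= 40000 nM in this assay, at which 2 of the 4 values shown sit.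

On these data alone, it stays open how far the two pyridine rings really lie from phenyl, as compound 2 and compound 3 each give only a limit and not a number. As far as these compounds go, it also stays open whether another group at this place on the phenyl ring, such as an amine, a carboxylic acid or a methoxy group, would move the number beyond the scatter in either direction.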